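This account rests on a few compounds, and the source may have more. Where it says the series, first, only, none or still open, it means among the compounds named here.

Three analogues of the shared core are in hand: compound 1 `COc1cc(-c2ccnc3cc(-c4ccc(Cl)cc4)nn23)cc(OC)c1OC`, compound 2 `COc1cc(-c2ccnc3cc(-c4ccc(C(C)=O)cc4)nn23)cc(OC)c1OC` and compound 3 `COc1cc(-c2ccnc3cc(-c4ccccc4)nn23)cc(OC)c1OC`. In a functional assay on HCT-116 cells (Homo sapiens) for inhibition, read by CCK-8 assay, with a stated time of 48 h (a lower number here means a stronger inhibitor, a higher number a weaker inhibitor), compound 1 gives 3340 nM, compound 2 gives 4390 nM and compound 3 gives 3880 nM. Compound 2 holds the highest of the three numbers, yet both other compounds sit within the scatter of it. Compound 4 `COc1cc(-c2ccnc3cc(-c4ccc(C)c(C)c4)nn23)cc(OC)c1OC` follows from compound 2 by 3,4-dimethylphenyl in place of 4-acetylphenyl on an aromatic carbon. The measured steps that bear on this change both altered the same phenyl ring and were a 1.3-fold higher number from compound 1 to compound 2 (0.12 log units; within the scatter) and a 1.1-fold lower number from compound 2 to compound 3 (0.05 log units; within the scatter), neither beyond the scatter, so varying that ring has so far left the number unmoved. The expected step is therefore a 1.2-fold lower number from compound 2 to compound 4 (0.06 log units; within the scatter), none beyond the scatter. The estimate for compound 4 is 3800 nM, with a range from 2000 nM to 7500 nM.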

Compound 4, half-maximal inhibitory concentration: 261 nM
The estimate for compound 4 lay 15-fold (1.16 log units) above the measured number; the measured number lies below the stated range.
By their numbers in this assay, from the lowest: compound 4; then compounds 1, 3 and 2 (each within the scatter of the next).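

In this assay, this position on the shared core is no longer silent: 3,4-dimethylphenyl separates compound 4 from all three earlier analogues, with a 17-fold lower number from compound 2 to compound 4 (1.23 log units; beyond the scatter), a 15-fold lower number from compound 3 to compound 4 (1.17 log units; beyond the scatter) and a 13-fold lower number from compound 1 to compound 4 (1.11 log units; beyond the scatter). The earlier rings, phenyl, 4-chlorophenyl and 4-acetylphenyl, remain within the scatter of one another, so the ring at this place can move the number after all. Nothing at hand accounts for the size of this step.

The compounds shown leave open whether a single methyl group on that phenyl ring would give the same step, and whether an ethyl chain or an amine there would keep it.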